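A Fluorophenyl Hydrazone Judged from Three Measured Analogues

This account rests on a few compounds, and the source may have more. Where it says the series, first, only, none or still open, it means among the compounds named here.

Of the compounds shown here, three built on one shared core have been measured in a functional assay on NCI-H460 cells (Homo sapiens) for cytotoxicity, read by MTT assay, with a stated time of 72 h; a lower number here means a stronger inhibitor, a higher number a weaker inhibitor. Compound 1 `COc1ccc(OC)c(/C=N/NC(=O)Nc2ccc(Oc3ccnc(-c4nncn4CCN(C)C)c3)c(F)c2)c1` gives 2930 nM. Compound 2 `CN(C)CCn1cnnc1-c1cc(Oc2ccc(NC(=O)N/N=C/c3cccc(O)c3)cc2F)ccn1` gives 780 nM. Compound 3 `CN(C)CCn1cnnc1-c1cc(Oc2ccc(NC(=O)N/N=C/c3ccccc3O[N+](=O)[O-])cc2F)ccn1` gives 1270 nM. Compound 3 stands second highest of the three numbers: its nearest value lies with compound 2 and its furthest with compound 1, since a 1.6-fold higher number from compound 2 to compound 3 (0.21 log units; within the scatter), whereas a 2.3-fold lower number from compound 1 to compound 3 (0.36 log units; beyond the scatter).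

Compound 4 `CN(C)CCn1cnnc1-c1cc(Oc2ccc(NC(=O)N/N=C/c3ccc(F)cc3)cc2F)ccn1` differs from compound 3 in a single place: 4-fluorophenyl in place of 2-(nitrooxy)phenyl on a carbon with a double bond to nitrogen. Within the data shown here, no measured step introduces the 4-fluorophenyl group, so the only guidance comes from the exchanges of the aryl group on the same carbon, namely a 3.8-fold lower number from compound 1 to compound 2 (0.57 log units; beyond the scatter) and a 2.3-fold lower number from compound 1 to compound 3 (0.36 log units; beyond the scatter), both modest, and from the closeness of compound 2 and compound 3 in this assay. These aryl changes moved the read-out only moderately, so no step beyond the scatter is expected in either direction. Compound 4 is therefore estimated to give about 1300 nM in this assay, with a range from 550 nM to 3100 nM. That estimate amounts to an expected 1.0-fold higher number from compound 3 to compound 4 (0.01 log units; within the scatter).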

Compound 4, half-maximal inhibitory concentration: 1980 nM
Compound 4: middle estimate off by 1.5-fold (0.18 log units), on the low side; measured number inside the range.
By their numbers in this assay, from the lowest: compounds 2, 3, 4 and 1 (each within the scatter of the next, the first and the last beyond it).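

In this assay, the 4-fluorophenyl group on this carbon separates from 3-hydroxyphenyl, with a 2.5-fold higher number from compound 2 to compound 4 (0.40 log units; beyond the scatter). It does not separate from the other two aryl groups, with a 1.6-fold higher number from compound 3 to compound 4 (0.19 log units; within the scatter) and a 1.5-fold lower number from compound 1 to compound 4 (0.17 log units; within the scatter), so exchanging 2-(nitrooxy)phenyl, with its 3 hydrogen-bond acceptors, for a group with none produced no step beyond the scatter. No measurement offered here accounts for these differences. Whether the hydroxyl itself sets compound 2 apart from compound 4 remains open, since only one hydroxylated aryl group is shown. As far as these compounds go, how a 4-aminophenyl or a 4-carboxyphenyl group on the same carbon would read in this assay also remains open.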